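The source may hold more compounds than are shown below. What is called first, only, known or untested is meant among the compounds shown, and "the series" means these compounds.

Among the measured compounds shown here, in an ADME assay on HCT-116 cells (Homo sapiens) for antiproliferative activity (a higher number here means a weaker inhibitor, a lower number a stronger inhibitor), three compounds have numbers so far: compound 1 `COc1ccc(C(C)=O)cc1COc1cccc(C)c1` gives 24000 nM, compound 2 `COc1ccc(C(C)=O)cc1COc1ccc(Cl)cc1` gives 39000 nM, and compound 3 `Cc1cc(OCc2cccc(C#N)c2)ccc1Cl` gives 45000 nM. Compound 2 lies within the scatter of both others, and these numbers set no order among the three. Compound 4 `COc1ccc(C(N)=O)cc1COc1ccc(Cl)cc1` shares the core of compound 2 and differs in one place, acetyl to carbamoyl: amino in place of methyl on a carbonyl carbon. For the measured compounds named here, no measured pair shows what a single change does here. Nothing beyond the scatter is expected in this assay, in either direction, and the expected change is a 1.0-fold higher number from compound 2 to compound 4 (0.01 log units; within the scatter). The estimated value for compound 4 is 40000 nM, with an expected range of 15000 nM to 100000 nM.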

Compound 4, half-maximal inhibitory concentration: > 50000 nM
Compound 4 gave a limit, no number (the forecaster's own chance of this, stated with the estimate: 20%); middle value at least 1.2-fold (0.09 log units) from the limit.
By their numbers in this assay, from the lowest: compounds 1, 2 and 3 (each within the scatter of the next). At a limit, above all of these: compound 4.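

Among the compounds shown here, the change from acetyl to carbamoyl gives the first step at a single place, read as an at least 1.2-fold higher number from compound 2 to compound 4 (0.10 log units; that floor lies within the scatter) in this assay. From the compounds shown here alone, compound 4 gives > 50000 nM, which is a limit of the assay and not a number, so the step has only a floor and its true size is unknown. The reading of this change ends at that limit: the limit of > 50000 nM in this assay, at which 1 of the 4 values shown sits.

Going by these compounds, whether the same change would give a similar step on the core of compound 1 stays open. Also open, on these data alone, is what a methylamino group or the hydroxyl of a carboxylic acid would give on that carbonyl carbon.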